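Fluoro substitution on the urea aryl in the pyrazolo series

This account rests on a few compounds, and the source may have more. Where it says the series, first, only, none or still open, it means among the compounds named here.

Measured compounds:
compound 1 `CCOC(=O)c1cnn2c1N(C(=O)Nc1ccccc1)C(c1ccccc1)C2`: 98 nM
compound 2 `CCOC(=O)c1cnn2c1N(C(=O)Nc1ccc(F)cc1)C(c1ccccc1)C2`: 10.3 nM
compound 3 `O=C(NC1CC1)c1cnn2c1N(C(=O)Nc1ccccc1)C(c1ccccc1)C2`: 123 nM

In a functional assay on cells (Neutrophil, Homo sapiens) for inhibition, with a stated time of 10 min (on this read-out higher numbers stand for weaker inhibition and lower numbers for stronger inhibition), compound 1 gives 98 nM. Compound 2 carries fluoro in place of hydrogen on an aromatic carbon and gives 10.3 nM; the step is a 9.5-fold lower number from compound 1 to compound 2 (0.98 log units; beyond the scatter). Compound 3 differs from compound 1 in the group on the carbonyl carbon, (cyclopropylamino in place of ethoxy on a carbonyl carbon). Compound 3 gives 123 nM, and the step of a 1.3-fold higher number from compound 1 to compound 3 (0.10 log units; within the scatter) is within the scatter, so the two cores cannot be told apart on this read-out.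

Compound 4 `O=C(NC1CC1)c1cnn2c1N(C(=O)Nc1cccc(F)c1)C(c1ccccc1)C2` is not yet measured. It relates to compound 3 as compound 2 relates to compound 1: fluoro in place of hydrogen on an aromatic carbon. The change is the same kind of change as that from compound 1 to compound 2, not the same, since the place differs: in compound 2 the fluoro sits para to a large group, in compound 4 meta to a large group. The measured instance of this kind of change, a 9.5-fold lower number from compound 1 to compound 2 (0.98 log units; beyond the scatter), is the only one in the set, and it was made on the other core and at the other place, so a direct transfer is uncertain.

The estimate for compound 4 in this assay is 45 nM, with a range from 12 nM to 130 nM. This means an expected step of a 2.7-fold lower number from compound 3 to compound 4 (0.44 log units; beyond the scatter), smaller than the measured one because a 9.5-fold lower number from compound 1 to compound 2 (0.98 log units; beyond the scatter) was seen at a different place and the core of compound 3 is itself unchanged within scatter.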

Compound 4, half-maximal inhibitory concentration: 138 nM
Estimate against measurement, compound 4: 3.1-fold (0.49 log units) below; the whole stated range lies below it.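

In this assay, the step to the 3-fluorophenyl group is a 1.1-fold higher number from compound 3 to compound 4 (0.05 log units; within the scatter), so on the core of compound 3 this fluoro leaves the read-out where it was, and the large drop seen on the core of compound 1 does not carry over as a general rule for the series: the same change on two cores in this assay, a 9.5-fold lower number (0.98 log units; beyond the scatter) from compound 1 to compound 2 and a 1.1-fold higher number (0.05 log units; within the scatter) from compound 3 to compound 4, 11-fold (1.03 log units) apart, beyond the scatter of two such steps. The two instances differ in two things at once, the group on the carbonyl carbon and the place of the fluoro on the ring, which is meta to a large group in compound 4 and elsewhere in compound 2. The gap therefore shows that the effect of fluoro is not a fixed increment across these compounds, but it does not show whether the core, the place of the fluoro or the two together set the size of the step.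

Open, going by these compounds, is how fluoro at the place it holds in compound 2 behaves on the core of compound 3, and how the 3-fluorophenyl group behaves on the core of compound 1, the two comparisons that would separate core from place. Also open, on these data alone, is whether chloro, methoxy or trifluoromethyl on the same phenyl ring follows either step.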